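A few compounds are considered here, and "the series" means these few. Any claim that something is new, unique, unknown or untested is made for them only; others in the source may bear on it.

Working notes on the series.

Compound 1 `CCCNC(=O)COc1ccc2cc(C(O)(C(F)(F)F)C(F)(F)F)c(O)cc2c1` carries the shared core with a propyl amide on the ether side chain. In an assay on isolated protein for inhibition of tyrosine-protein phosphatase non-receptor type 13 (Homo sapiens), read by spectrophotometry (a higher number here means a weaker inhibitor, a lower number a stronger inhibitor), compound 1 gives only a limit, > 20000 nM, so its standing in this assay is known as a floor of weak inhibition rather than as a number (the limit of > 20000 nM in this assay, at which 1 of the 2 values shown sits). Compound 2 `Oc1ccc(-c2ccccc2)cc1C(O)(C(F)(F)F)C(F)(F)F`, a simpler analogue of the same carbinol, likewise gives only a limit in this assay, > 500000 nM (the limit of > 500000 nM in this assay, at which 1 of the 2 values shown sits). Among the measured compounds shown here, no step between measured compounds can be drawn from two limits.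

Compound 3 `COc1ccc(CNC(=O)COc2ccc3cc(C(O)(C(F)(F)F)C(F)(F)F)c(O)cc3c2)cc1OC` has not yet been measured in this assay. It differs from compound 1 by 3,4-dimethoxyphenyl in place of ethyl on a saturated chain carbon bound to an amide-type nitrogen. With compound 1 known only as a limit, the size of the step is uncertain. The step is estimated to be about an at least 2.0-fold lower number from compound 1 to compound 3 (0.30 log units; that floor lies within the scatter), which would be a gain beyond the scatter, expected but not assured. Compound 3 is expected to show about 10000 nM, within 2000 nM to 50000 nM.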

Compound 3, half-maximal inhibitory concentration: > 20000 nM
Compound 3 gave a limit, no number (the forecaster's own chance of this, stated with the estimate: 45%); at least 2.0-fold (0.30 log units) between middle value and limit.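

Among the compounds shown here, compound 1 and compound 3 both stand only as limits in this assay, and no step between them can be read. The compounds shown leave open whether 3,4-dimethoxyphenyl in place of ethyl changes inhibition at all, and what actual number either compound would give.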